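The source may hold more compounds than are shown below. What is called first, only, known or untested is meant among the compounds shown, and "the series" means these compounds.

Three compounds share one core and differ only in their substituents. Compound 1 `N=C(N)c1ccc(-c2ccc(-c3cc(Cl)cc(Cl)c3)s2)cc1`, compound 2 `N=C(N)c1ccc(-c2ccc(-c3ccc(F)cc3)s2)cc1` and compound 3 `N=C(N)c1ccc(-c2ccc(-c3ccc(Cl)cc3)s2)cc1F` were all tested in a functional assay on SK-MEL-2 cells (Homo sapiens) for inhibition, read by sulforhodamine B assay, with a stated time of 48 h; a higher number here means a weaker inhibitor of growth, a lower number a stronger inhibitor of growth. In this assay compound 1 gives 1990 nM, compound 2 gives 2050 nM, and compound 3 stands at 1500 nM, with the numbers of compound 1 and compound 2 both lying within the scatter of it, so the three cannot be told apart. Compound 4 `N=C(N)c1ccc(-c2ccc(-c3ccccc3)s2)cc1F` is the next compound to be measured. It differs from compound 3 by hydrogen in place of chloro on an aromatic carbon. No comparable single change is available among the measured compounds, so the step from compound 3 to compound 4 in this assay is expected to be small, if anything toward a higher number, and not beyond the scatter, giving a 1.5-fold higher number from compound 3 to compound 4 (0.19 log units; within the scatter). Compound 4 is therefore estimated at 2300 nM, with a range from 1000 nM to 5500 nM.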

Compound 4, concentration for 50% growth inhibition: 4910 nM
Estimate against measurement, compound 4: 2.1-fold (0.33 log units) below; measured number inside the range.
By their numbers in this assay, from the lowest: compounds 3, 1 and 2 (each within the scatter of the next); then compound 4.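

Replacing chloro with hydrogen in this assay gives a 3.3-fold higher number from compound 3 to compound 4 (0.51 log units; beyond the scatter) and so weakens growth inhibition. This is the first difference among these compounds that stands beyond the scatter, and it shows that the chloro on this aromatic carbon matters in this pair. No measurement shown here accounts for the step. From the compounds shown here alone, whether a methoxy group or an amine in the same place would match chloro or hydrogen remains open. So does whether the 4-chlorophenyl to phenyl change would have a similar effect in a compound without the fluoro of compound 3.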